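A few compounds are considered here, and "the series" means these few. Any claim that something is new, unique, unknown or untested is made for them only; others in the source may bear on it.

Measured compounds:
Compound 1, `Cc1ccc(N2CCN(CCC3NC(=O)c4ccccc43)CC2)cc1`, gives 12.4 nM in an assay on CHO cells for binding affinity to D(4) dopamine receptor (Homo sapiens); a higher number here means a weaker inhibitor, a lower number a stronger inhibitor.
Compound 2, `O=C1NC(CCN2CCN(c3ccccc3)CC2)c2ccccc21`, gives 24.5 nM in this assay.

Within the data shown here, compound 2 holds the higher of the two numbers, and the only step that reaches it, a 2.0-fold higher number from compound 1 to compound 2 (0.30 log units; within the scatter), lies within the scatter, so the two compounds cannot be separated by this measurement. Compound 3, `O=C1NC(CCN2CCN(c3ccc(Cl)cc3)CC2)c2ccccc21`, differs from compound 2 in one place: chloro in place of hydrogen on an aromatic carbon, on an aromatic carbon of a six-membered aromatic ring of carbon only, para to a large group. Among the measured compounds shown here, no measured step carries a chloro group. For the measured compounds named here, the one step that touches this position concerns methyl and stays within the scatter, which gives little reason to expect a marked change for a chloro group either. For compound 3 a small step is therefore expected in this assay, a 1.5-fold lower number from compound 2 to compound 3 (0.19 log units; within the scatter), with no confident direction. Compound 3 is expected to give 16 nM, within a range of 5 nM to 50 nM.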

Compound 3, inhibition constant: 27.8 nM
Estimate against measurement, compound 3: 1.7-fold (0.24 log units) below; the range from low to high includes it.
By their numbers in this assay, from the lowest: compounds 1, 2 and 3 (each within the scatter of the next, the first and the last beyond it).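

The change from phenyl to 4-chlorophenyl gives a 1.1-fold higher number from compound 2 to compound 3 (0.05 log units; within the scatter), so in this assay a chloro group on this aromatic carbon, para to a large group, cannot be told apart from hydrogen. Chloro in place of methyl at the same place gives a 2.2-fold higher number from compound 1 to compound 3 (0.35 log units; beyond the scatter), the first step in the series to pass the scatter, though only modestly, so the two groups can be separated here even though neither is separated from hydrogen. Nothing available bears on the reason for these results.

The compounds shown leave open how other groups at this place, such as a methoxy group, an amine or a carboxylic acid, would behave. They also leave open what a longer chain between the shared core and the rest of the molecule would do.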